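The source may hold more compounds than are shown below. What is called first, only, known or untested is meant among the compounds shown, and "the series" means these compounds.

Compound 1 `N#CNC(=N)Nc1cccnc1`: 50 mg/kg
Compound 2 `CCC/N=C(\NC#N)Nc1cccnc1`: 20 mg/kg

Both numbers come from a functional assay on the whole organism (blood, strain Wistar-Okamoto) with Rattus norvegicus as the target, with a stated time of 5 days; on this read-out lower numbers stand for an effect already at smaller amounts and higher numbers for an effect only at larger amounts of compound. Compound 2 stands lowest of the two numbers; the nearest is compound 1, whose number is higher by a margin beyond the usual scatter. Compound 3 `CCCCC/N=C(\NC#N)Nc1cccnc1` differs from compound 2 by ethyl in place of hydrogen on a saturated chain carbon, three bonds along the chain from a double-bonded nitrogen. For the measured compounds named here, no step of this kind has been measured, so nothing here tells how far this change moves the number. The expected step, no change at the digits printed from compound 2 to compound 3 (within the scatter), is none beyond the scatter, with no clear direction. Compound 3 is estimated at 20 mg/kg, within a range from 10 mg/kg to 40 mg/kg.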

Compound 3, minimum effective dose: 20 mg/kg
The estimate for compound 3 equals the measured number at the digits printed; low and high end bracket the measured number.
By their numbers in this assay, from the lowest: compounds 2 and 3 (each within the scatter of the next); then compound 1.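

Ethyl in place of hydrogen on a saturated chain carbon, three bonds along the chain from a double-bonded nitrogen, gives in this assay the first measured step of the series: no change at the digits printed from compound 2 to compound 3 (within the scatter) for propyl to pentyl. This position therefore takes the added ethyl with the number held within the scatter.

As far as these compounds go, whether a longer chain such as heptyl, a branched chain, or a chain ending in an amine would hold or move the number remains open. Nothing at hand bears on the reason for this result.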